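Series notes: aryl sulfonamide pyrazine antagonists, step to compound 4

This account rests on a few compounds, and the source may have more. Where it says the series, first, only, none or still open, it means among the compounds named here.

Measured so far:
compound 1 `CC(C)(C)c1ccc(S(=O)(=O)Nc2ccc(Cl)cc2-c2nccnc2NCCO)cc1`: 34 nM
compound 2 `CC(C)(C)c1ccc(S(=O)(=O)Nc2ccc(Cl)cc2-c2nccnc2NCCCO)cc1`: 614 nM
compound 3 `Cc1cnc(-c2cc(Cl)ccc2NS(=O)(=O)c2ccc(C(C)(C)C)cc2)c(NCCO)n1`: 268 nM

In a functional assay on isolated protein for antagonist activity at C-C chemokine receptor type 9 (Homo sapiens), read by calcium flux, with a stated time of 10 min (on this read-out lower numbers stand for stronger inhibition and higher numbers for weaker inhibition), compound 1 gives 34 nM and stands lowest of the three. Compound 3 stands second highest, between compound 1 and compound 2, separated from each by more than the scatter. The two measured steps both lead away from compound 1: an 18-fold higher number from compound 1 to compound 2 (1.26 log units; beyond the scatter) for a longer chain, and a 7.9-fold higher number from compound 1 to compound 3 (0.90 log units; beyond the scatter) for a substituent placed on the aromatic ring.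

Compound 4 `CNc1cnc(-c2cc(Cl)ccc2NS(=O)(=O)c2ccc(C(C)(C)C)cc2)c(NCCO)n1` is not yet measured. It differs from compound 3 by methylamino in place of methyl on an aromatic carbon. Among the measured compounds shown here, no measured pair exchanges methyl for methylamino, so neither step bears directly on this change; the only related observation is that placing a group at this ring carbon, from compound 1 to compound 3, raised the number. With the substituent retained and enlarged, a modest rise, or no step beyond the scatter, is the expectation, and the estimated step is a 1.7-fold higher number from compound 3 to compound 4 (0.23 log units; within the scatter). Compound 4 is therefore expected to give about 450 nM in this assay, with a range from 120 nM to 1700 nM.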

Compound 4, half-maximal inhibitory concentration: 1010 nM
Compound 4: middle estimate off by 2.2-fold (0.35 log units), on the low side; low and high end bracket the measured number.
By their numbers in this assay, from the lowest: compound 1; then compound 3; then compounds 2 and 4 (each within the scatter of the next).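

In this assay, methylamino in place of methyl on this aromatic carbon gives a 3.8-fold higher number from compound 3 to compound 4 (0.58 log units; beyond the scatter), so the read-out at this position depends on which group is present and not only on the carbon being substituted. Set against hydrogen at the same carbon, methylamino gives a 30-fold higher number from compound 1 to compound 4 (1.47 log units; beyond the scatter), compared with a 7.9-fold higher number from compound 1 to compound 3 (0.90 log units; beyond the scatter) for methyl, and among these three groups hydrogen therefore gives the lowest number and neither substituent improves on it. Nothing measured here accounts for the rise.

The compounds shown leave open how methoxy, dimethylamino or a chlorine atom would read at this carbon, and so whether any substituent there can match hydrogen. Also open, from the compounds shown here alone, is whether the methylamino step would hold with the longer chain of compound 2.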